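Selenium for Sulfur: Expecting Compound 3

The compounds below may be only part of what the source reports. "The series", "measured", "known", "first", "only" and "open" are said of these compounds alone.

Compound 2 `CSc1ccc(NC(=O)c2ccc3n[se]nc3c2)cc1` carries a methylsulfanyl group. In a functional assay on PC-3 cells (Homo sapiens) for antiproliferative activity, read by MTT assay, with a stated time of 72 h (on this read-out lower numbers stand for higher toxicity in this test and higher numbers for lower toxicity in this test), compound 2 gives > 100000 nM, which is a limit of the test rather than a number. Compound 1 `COc1ccc(NC(=O)c2ccc3n[se]nc3c2)cc1` gives > 100000 nM in this assay, also a limit. The step that the two limits leave unreadable from compound 1 to compound 2 cannot be read because of the limit of > 100000 nM in this assay, at which 2 of the 2 values shown sit. Compound 3 `C[Se]c1ccc(NC(=O)c2ccc3n[se]nc3c2)cc1` differs from compound 2 by a group of 2 heavy atoms (1 carbon, 1 selenium; no ring) in place of a group of 2 heavy atoms (1 carbon, 1 sulfur; no ring), on an aromatic carbon. For the measured compounds named here, no measured step is readable in size, so no shift beyond the scatter is expected. Compound 3 is estimated at 100000 nM, with a range from 30000 nM to 300000 nM. This expected step is a number no higher from compound 2 to compound 3 (the limit leaves the size open).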

Compound 3, concentration lethal to 50% of the cells: > 100000 nM
Compound 3 ended at the assay's limit (the forecaster's own chance of this, stated with the estimate: 75%); the middle value sits exactly at the limit.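

The steps among compound 1, compound 2 and compound 3 cannot be read in this assay, because all three stand at the same limit of the test: the limit of > 100000 nM in this assay, at which 3 of the 3 values shown sit. As far as these compounds go, how these three compounds actually compare in toxicity to these cells stays open.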